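This account rests on a few compounds, and the source may have more. Where it says the series, first, only, none or still open, it means among the compounds named here.

Three measured compounds share one core: compound 1 `COc1ccc(OC)c(N2C(=O)CSC2c2cccc(C(=O)NCCCCc3ccccc3)c2)c1`, compound 2 `COc1cccc(OC)c1N1C(=O)CSC1c1cccc(C(=O)NCCCCc2ccccc2)c1` and compound 3 `O=C(NCCCCc1ccccc1)c1cccc(C2SCC(=O)N2c2ccccc2)c1`. In a functional assay on 143B cells (Homo sapiens) for inhibition, read by CCK-8 assay, with a stated time of 72 h, tested at 1 uM (a higher number here means more inhibition at the concentration tested (going by the name of the read-out), a lower number less inhibition), compound 1 gives 2%, compound 2 gives 31% and compound 3 gives 60%, so compound 3 stands highest of the three, with compound 2 nearest and compound 1 furthest. All three steps change only the ring on the amide-type nitrogen: a number 29 percentage points higher from compound 1 to compound 2 (beyond the scatter), a number 58 percentage points higher from compound 1 to compound 3 (beyond the scatter) and a number 29 percentage points higher from compound 2 to compound 3 (beyond the scatter). Compound 4 `O=C(NCCCCc1ccccc1)c1cccc(C2SCC(=O)N2c2ccccc2F)c1` is the next step from compound 3: fluoro in place of hydrogen on an aromatic carbon. The two steps that lead to compound 3 each replaced a dimethoxyphenyl with a bare phenyl and raised inhibition, so the change here, which adds a substituent to that same ring, points the other way, though a fluoro is a much smaller addition than the methoxy groups that were removed. A modest fall is therefore expected, a number 15 percentage points lower from compound 3 to compound 4 (beyond the scatter). Compound 4 is estimated at 45%, with a range from 20% to 70%.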

Compound 4, a percentage reported as inhibition, at one concentration (the size of the read-out at that concentration, not a potency): 59%
Compound 4: the middle estimate sits 14 percentage points below what was measured; measured number inside the range.
By their numbers in this assay, from the lowest: compound 1; then compound 2; then compounds 4 and 3 (each within the scatter of the next).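

In this assay, a fluoro on the ring of the amide-type nitrogen, ortho to a large group, leaves the read-out within the scatter of the bare phenyl: a number 1 percentage points lower from compound 3 to compound 4 (within the scatter). A substituent on this ring therefore does not in itself bring the lower numbers of the two dimethoxyphenyl compounds, as the 2-fluorophenyl compound shows with a number 28 percentage points higher from compound 2 to compound 4 (beyond the scatter) and a number 57 percentage points higher from compound 1 to compound 4 (beyond the scatter). No measurement at hand accounts for this difference between the fluoro and the methoxy groups.

The compounds shown leave open whether a single methoxy, a chloro or a methyl on this ring would read like the fluoro or like the dimethoxyphenyl compounds. They also leave open how an amine or a carboxylic acid on this ring would read at this one concentration.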